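The source may report more compounds than this note shows. Statements on the series, on what has been measured and on what is new or still open speak of the compounds shown alone.

In a functional assay on ECa-109 cells for inhibition, with ECa-109 cell line (Homo sapiens) as the target, read by sulforhodamine B assay (a higher number here means a weaker inhibitor, a lower number a stronger inhibitor), three compounds sharing one core have been measured. Compound 2 (`O=C1C=C(Nc2ccccc2F)C(=O)c2c1nc1n2[C@H]2OC[C@@H](O)[C@H]2OC1`) gives 2760 nM, its isomer compound 1 (`O=C1C(Nc2ccccc2F)=CC(=O)c2c1nc1n2[C@H]2OC[C@@H](O)[C@H]2OC1`) gives 2660 nM, and compound 3 (`Cc1ccc(NC2=CC(=O)c3c(nc4n3[C@H]3OC[C@@H](O)[C@H]3OC4)C2=O)cc1C`) gives 4090 nM. Compound 2 thus stands within the scatter of both the others, and no order can be read among the three.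

Compound 4 (`O=C1C=C(Nc2ccc(Br)cc2)C(=O)c2c1nc1n2[C@H]2OC[C@@H](O)[C@H]2OC1`) departs from compound 2 at a single place: 4-bromophenyl in place of 2-fluorophenyl on an amine nitrogen. In words, it carries 4-bromophenyl in place of 2-fluorophenyl on an amine nitrogen.

Among the measured compounds shown here, only one measured step bears on this change, the exchange of 2-fluorophenyl for 3,4-dimethylphenyl on an amine nitrogen. For the measured compounds named here, it was taken on the isomer rather than on compound 2 itself, so it carries over only by analogy, and no compound bearing bromine has yet been measured. Going by the values given here, with a 1.5-fold higher number from compound 1 to compound 3 (0.19 log units; within the scatter) as the sole guide, a step that stays within the scatter, no shift beyond the scatter is expected in this assay, and no direction can be favoured. The estimated change is a 1.1-fold higher number from compound 2 to compound 4 (0.04 log units; within the scatter). For compound 4 the expected value is 3000 nM, with an estimated range from 1400 nM to 6500 nM.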

Compound 4, half-maximal inhibitory concentration: 2850 nM
Beside the measured number, compound 4's estimate is 1.1-fold (0.02 log units) above it; low and high end bracket the measured number.
By their numbers in this assay, from the lowest: compounds 1, 2, 4 and 3 (each within the scatter of the next).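

Among the compounds shown here, the exchange of 2-fluorophenyl for 4-bromophenyl on the amine nitrogen, read in this assay, gives a 1.0-fold higher number from compound 2 to compound 4 (0.01 log units; within the scatter), which is the first step taken on the arrangement of compound 2 itself and the first to bring in bromine. Together with a 1.5-fold higher number from compound 1 to compound 3 (0.19 log units; within the scatter) on the isomer, it shows that two different substituted phenyl groups at this place, on both arrangements of the core, give steps that stay within the scatter, so this place has not yet shown any measurable sensitivity to the change of phenyl substituent. No available evidence accounts for this result.

As far as these compounds go, all the groups on this nitrogen so far are substituted phenyl rings, so it remains open whether a group of another kind, such as a pyridine ring, a cyclohexyl ring, a straight alkyl chain or a phenyl ring bearing a carboxylic acid, would move the number beyond the scatter. For the compounds shown here, it is also open whether 4-bromophenyl on the isomer, compound 1's arrangement, would give a value in line with the one for compound 4.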